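A few compounds are considered here, and "the series" means these few. Any claim that something is new, unique, unknown or untested is made for them only; others in the source may bear on it.

Two hydroxamic acids of the shared core carry numbers in a functional assay on NUGC-3 cells (Homo sapiens) for inhibition, read by sulforhodamine B assay; a higher number here means a weaker inhibitor of growth, a lower number a stronger inhibitor of growth. Compound 1 `O=C(CCC1=CCN(CCCc2ccc(Br)cc2)C1=O)NO` gives 2200 nM, the lowest of the two numbers. Compound 2 `Cc1cccc(CN2CC=C(CCC(=O)NO)C2=O)c1` gives 4280 nM; the gap between these two values lies within the scatter, so the two compounds cannot be separated on what is known. For the measured compounds named here, no pair of measured compounds differs in a single place, so no measured step in this assay serves as a guide. Compound 3 `O=C(CCC1=CCN(CCCc2ccc(Cl)cc2)C1=O)NO` has not been measured; it differs from compound 1 thus: chloro in place of bromo on an aromatic carbon. Bromo leaves and chloro enters, with no change in ring count, donor or acceptor count, or charge. With nothing measured to anchor such an exchange, the step is expected to be small, not beyond the scatter in either direction: a 1.1-fold higher number from compound 1 to compound 3 (0.06 log units; within the scatter). Compound 3 is therefore estimated at 2500 nM, within 1100 nM to 5600 nM.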

Compound 3, concentration for 50% growth inhibition: 2200 nM
Beside the measured number, compound 3's estimate is 1.1-fold (0.06 log units) above it, within the range that was stated.
By their numbers in this assay, from the lowest: compounds 1, 3 and 2 (each within the scatter of the next).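

In this assay the series now has its first measured step in one place, 4-bromophenyl to 4-chlorophenyl, with no change at the digits printed from compound 1 to compound 3 (within the scatter) as its reading. On this aromatic carbon, para to a large group, bromo and chloro cannot be told apart, so this exchange offers no handle on growth inhibition, and the bromine atom of compound 1 is not needed to hold its number. No measurement at hand bears on why the two halogens read alike.

From the compounds shown here alone, whether a fluoro, a methoxy, an amine or a carboxylic acid in this place would move the number remains open. Also open, going by these compounds, is whether a longer chain linking the aromatic ring to the shared core would leave the number where it stands.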